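This account rests on a few compounds, and the source may have more. Where it says the series, first, only, none or still open, it means among the compounds named here.

Values in a functional assay on HepG2 cells (Homo sapiens) for antiproliferative activity, read by MTT assay, with a stated time of 48 h; a lower number here means a stronger inhibitor, a higher number a weaker inhibitor:

- Compound 1 `CCCCOc1ccc(C(=O)/C=C/c2c(/C=C/c3ccc(OC)cc3)cc(OC)cc2OC)cc1` gives 12.9 ug/mL
- Compound 2 `COc1ccc(/C=C/c2cc(OC)cc(OC)c2/C=C/C(=O)c2ccc(N)cc2)cc1` gives 7.5 ug/mL
- Compound 3 `COc1ccc(/C=C/c2cc(OC)cc(OC)c2/C=C/C(=O)c2ccc(Cl)cc2)cc1` gives 13.6 ug/mL

The numbers do not separate compound 3 from the other two. Its neighbouring steps are a 1.1-fold higher number from compound 1 to compound 3 (0.02 log units; within the scatter) and a 1.8-fold higher number from compound 2 to compound 3 (0.26 log units; within the scatter), and the remaining step is a 1.7-fold lower number from compound 1 to compound 2 (0.24 log units; within the scatter). All three lie within the scatter.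

Next in the series is compound 4 `COc1ccc(/C=C/c2cc(OC)cc(OC)c2/C=C/C(=O)c2ccc(OC)cc2)cc1`, with methoxy in place of chloro on an aromatic carbon, para to a large group: methoxy in place of chloro on an aromatic carbon.

All three measured steps bear on this change, since each exchanges the group at this same place. Across butoxy, amino and chloro, none has moved the number beyond the scatter, a pattern that rests on these three compounds alone. Compound 1, which carries butoxy, is the closest comparison by group name, and a 1.1-fold higher number from compound 1 to compound 3 (0.02 log units; within the scatter) is the smallest of the steps. No measurement of methoxy at this place exists yet.

No step beyond the scatter is therefore expected in this assay, and no direction can be called. The expected change is a 1.1-fold lower number from compound 3 to compound 4 (0.05 log units; within the scatter), which remains within the scatter.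

For compound 4 the estimated value is 12 ug/mL, with an expected range from 6.5 ug/mL to 22 ug/mL.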

Compound 4, half-maximal inhibitory concentration: 4.9 ug/mL
The estimate for compound 4 lay 2.4-fold (0.39 log units) above the measured number; the whole stated range lies above it.
By their numbers in this assay, from the lowest: compounds 4, 2, 1 and 3 (each within the scatter of the next, the first and the last beyond it).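

In this assay, the place on an aromatic carbon para to a large group now gives its first steps beyond the scatter, both modest: a 2.8-fold lower number from compound 3 to compound 4 (0.44 log units; beyond the scatter) for methoxy in place of chloro, and a 2.6-fold lower number from compound 1 to compound 4 (0.42 log units; beyond the scatter) for methoxy in place of butoxy. The group at this place can therefore shift the number, which the three earlier compounds did not show, although methoxy is not separated from amino, with a 1.5-fold lower number from compound 2 to compound 4 (0.18 log units; within the scatter), and compound 2 remains within the scatter of both compound 1 and compound 3. No measured evidence accounts for these steps.

The compounds shown leave open whether the difference between methoxy and butoxy reflects chain length, since an ethoxy or propoxy group at this place would be needed to show how the number changes between these two. They also leave open whether a hydroxy group or a fluoro group here would group with methoxy and amino or with chloro and butoxy, and whether any such step holds outside this one cell assay.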